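Swapping chloro for methyl on a cleared compound

The source may report more compounds than this note shows. Statements on the series, on what has been measured and on what is new or still open speak of the compounds shown alone.

Compound 1 `CC(=O)N[C@@H]1CCC[C@H](C(=O)Nc2cc(-c3cnn4c3CC(C)(C)C4)ccn2)C1` gives < 3 mL.min-1.g-1 as a limit of the assay
Compound 2 `CC(=O)N[C@@H]1CCC[C@H](C(=O)Nc2cc(-c3cnn4c3CC(C)(C)C4)c(Cl)cn2)C1` gives 50 mL.min-1.g-1 as a measured number

For the measured compounds named here, in an ADME assay on microsomes from liver (Homo sapiens) for metabolic stability (on this read-out lower numbers stand for slow clearance and higher numbers for fast clearance), compound 2 stands at 50 mL.min-1.g-1 as the only true number so far. Compound 1 is known only as a limit.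

Compound 3 `CC(=O)N[C@@H]1CCC[C@H](C(=O)Nc2cc(-c3cnn4c3CC(C)(C)C4)c(C)cn2)C1` changes compound 2 at a single spot, with methyl in place of chloro on an aromatic carbon and everything else kept.

Going by the values given here, one measured step bears on this. Putting chloro in place of hydrogen on that same carbon gave an at least 16-fold higher number from compound 1 to compound 2 (1.22 log units; beyond the scatter) in this assay and this large change shows that the spot can matter. That step compares chloro with hydrogen, however, and no methyl has been measured here. Compound 3 still carries a single heavy atom at that carbon, as compound 2 does, so its number is expected to stay closer to compound 2 than to compound 1, perhaps slightly lower.

The expected change is a 1.7-fold lower number from compound 2 to compound 3 (0.22 log units; within the scatter) and it is not expected to lie beyond the scatter. Compound 3 is estimated at 30 mL.min-1.g-1 with an expected range from 8 mL.min-1.g-1 to 80 mL.min-1.g-1 for this measurement.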

Compound 3, intrinsic clearance in microsomes: 19 mL.min-1.g-1
Estimate against measurement, compound 3: 1.6-fold (0.20 log units) above; measured number inside the range.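

In this assay, methyl in place of chloro on this aromatic carbon gives a 2.6-fold lower number from compound 2 to compound 3 (0.42 log units; beyond the scatter), so two groups of one heavy atom each are not interchangeable at this spot. Methyl in place of hydrogen on the same carbon gives an at least 6.3-fold higher number from compound 1 to compound 3 (0.80 log units; beyond the scatter), which shows that the rise seen earlier is not unique to chloro: both groups tried here move the number the same way from hydrogen, and chloro moves it further. The value of compound 1 is a limit of the assay, so the full size of each rise from hydrogen stays unknown: the limit of < 3 mL.min-1.g-1 in this assay, at which 1 of the 3 values shown sits.

Going by these compounds, it remains open whether other groups on this carbon, such as fluoro, methoxy, a nitrile or an amine, would also raise the number or would keep it close to that of hydrogen. The compounds shown also cannot tell why either chloro or methyl raises the number, or whether the same order of hydrogen, methyl and chloro would hold on a different core.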